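The compounds below may be only part of what the source reports. "The series", "measured", "known", "first", "only" and "open" are said of these compounds alone.

Measured in a functional assay on A549 cells (Homo sapiens) for antiproliferative activity, read by MTT assay, with a stated time of 48 h; a higher number here means a weaker inhibitor, a lower number a stronger inhibitor:
- compound 1 `COc1ccc(N2CCN(Cc3ccc4c(c3O)-c3ccc(cc3O)CCc3ccc(O)c(c3)Oc3ccc(cc3)CC4)CC2)cc1`: > 20000 nM (a limit)
- compound 2 `CN1CCN(Cc2ccc3c(c2O)-c2ccc(cc2O)CCc2ccc(O)c(c2)Oc2ccc(cc2)CC3)CC1`: 5590 nM

Within the data shown here, compound 2 holds the only actual number so far. The entry for compound 1 is a limit of this assay, not a number.

Compound 3 `CN1CCN(Cc2cc3cc(c2O)Oc2ccc(cc2)CCc2ccc(CN4CCN(C)CC4)c(O)c2-c2ccc(cc2O)CC3)CC1` differs from compound 2 by (4-methylpiperazin-1-yl)methyl in place of hydrogen on an aromatic carbon, ortho to a hydroxy group. Compound 2 already carries this group elsewhere on the core.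

Among the measured compounds shown here, the one measured step is an at least 3.5-fold lower number from compound 1 to compound 2 (0.55 log units; beyond the scatter), with methyl in place of 4-methoxyphenyl on an amine nitrogen in a ring. It bears only indirectly, since it exchanges a substituent on the amine and adds no second side chain. For the measured compounds named here, no measured step shows what such an addition does, so no firm direction can be drawn from it.

The expected outcome is a 1.2-fold lower number from compound 2 to compound 3 (0.09 log units; within the scatter), with no shift beyond the scatter anticipated. The estimate for compound 3 is 4500 nM, with an expected range of 1500 nM to 14000 nM.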

Compound 3, half-maximal inhibitory concentration: 2160 nM
Beside the measured number, compound 3's estimate is 2.1-fold (0.32 log units) above it, and the stated range covers the measured number.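

In this assay there is a 2.6-fold lower number from compound 2 to compound 3 (0.41 log units; beyond the scatter), with (4-methylpiperazin-1-yl)methyl in place of hydrogen on an aromatic carbon, ortho to a hydroxy group. Among these compounds, this is the first measured change at this position, and it shows that a second copy of the side chain already present in compound 2 lowers the number rather than raising it, whereas the earlier pair differed only in the substituent on the ring amine nitrogen. No measured property shown here accounts for this step.

Going by these compounds, it remains open whether the step depends on the 4-methylpiperazine ring itself, which a morpholin-4-ylmethyl or dimethylaminomethyl group on this aromatic carbon would address. Also open, on these data alone, is how a longer chain linking the piperazine ring to this carbon would read in this assay here.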